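The compounds below may be only part of what the source reports. "The series", "measured", "known", "first", "only" and "open" are said of these compounds alone.

Measured compounds:
compound 1, `C=Cc1cccc(C(=O)N2CCCC(C(=O)Nc3ccc(Cl)cc3)C2)c1` — 0%
compound 2, `COC(=O)c1cccc(NC(=O)C2CCCN(C(=O)c3cc(C(F)(F)F)cc(C(F)(F)F)c3)C2)c1` — 0%
compound 3, `O=C(Nc1ccc(Cl)cc1)C1CCCN(C(=O)c2ccc(-c3ccco3)cc2)C1` — 6%

Three compounds sharing the same core were tested in an ADME assay on PC-3 cells (Homo sapiens) for cytotoxicity, read by WST assay, tested at 100 uM; on this read-out lower numbers stand for less inhibition and higher numbers for more inhibition at the one concentration tested (going by the name of the read-out). In this assay compound 1 gives 0%, compound 2 gives 0% and compound 3 gives 6%. Compound 2 stands level with compound 1 at the digits shown, and the reading of compound 3 lies within the usual scatter of both, so none of the three can be set apart from the others on these numbers; at the single concentration tested, all three sit at the floor of the read-out.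

The step from compound 2 to compound 4 leaves the core untouched and alters only the amide substituent on the aromatic ring: phenyl in place of methoxy on a carbonyl carbon. Compound 4, `O=C(c1ccccc1)c1cccc(NC(=O)C2CCCN(C(=O)c3cc(C(F)(F)F)cc(C(F)(F)F)c3)C2)c1`, has not yet been measured in this assay.

For the measured compounds named here, no step between measured compounds is available for this change, and the three measured compounds give no sign that a larger aromatic group, such as the furyl group of compound 3, lifts the reading beyond the scatter. The step from compound 2 to compound 4 is therefore expected to be a number 3 percentage points higher from compound 2 to compound 4 (within the scatter), that is, no change beyond the scatter. For compound 4 the expected reading is 3%, with a range from 0% to 15%.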

Compound 4, a percentage reported as inhibition, at one concentration (the size of the read-out at that concentration, not a potency): 0%
Beside the measured number, compound 4's estimate is 3 percentage points above it, within the range that was stated.
By their numbers in this assay, from the lowest: compounds 1, 2, 4 and 3 (each within the scatter of the next).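

In this assay, the exchange of methoxy for phenyl on a carbonyl carbon, which reads as methoxycarbonyl to benzoyl when cut one bond further out, gives no change at the digits printed from compound 2 to compound 4 (within the scatter). For the compounds shown here, this is the first step at this position that can be read, since the earlier compounds offered no pair differing in one place. It shows that the position accepts a six-membered aromatic ring of carbon only, where no ring stood before, and the loss of the methoxy group's hydrogen-bond acceptor, without the reading leaving the floor of the scale. No measurement bearing on the cause of this reading is available.

With compound 2 and compound 4 both at the floor, the step can show only that no rise appears at the one concentration tested, and it could not register any fall. What the compounds shown leave open is whether a different group on this carbonyl carbon, such as a hydroxyl giving a carboxylic acid, an amine giving an amide, or a longer alkyl chain, would move the reading beyond the scatter.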